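From Bromophenyl to Dichlorophenyl: Expecting Compound 4

This account rests on a few compounds, and the source may have more. Where it says the series, first, only, none or still open, it means among the compounds named here.

Of the compounds shown here, three built on one shared core have been measured in a functional assay on Huh-7 cells (Homo sapiens) for inhibition, read by sulforhodamine B assay, with a stated time of 72 h; a higher number here means a weaker inhibitor, a lower number a stronger inhibitor. Compound 1 `Cc1ccc(C2=Nn3c(nnc3C(C)c3ccc(-c4ccccc4)c(F)c3)SC2)cc1` gives 7200 nM. Compound 2 `CC(C)Cc1ccc(C(C)c2nnc3n2N=C(c2ccc(Br)cc2)CS3)cc1` gives 4900 nM, and compound 3 `COc1ccc2cc(C(C)c3nnc4n3N=C(c3ccc(F)cc3)CS4)ccc2c1` gives 7000 nM. Compound 2 carries the lowest of these three numbers, yet its gaps to compound 3 and to compound 1 both fall within the usual scatter of repeated measurements, so no order among the three can be read from these values.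

Compound 4 `CC(C)Cc1ccc(C(C)c2nnc3n2N=C(c2ccc(Cl)cc2Cl)CS3)cc1` has not yet been measured. It differs from compound 2 in a single place: 2,4-dichlorophenyl in place of 4-bromophenyl on a carbon with a double bond to nitrogen. Within the data shown here, no pair of measured compounds shows a change of this kind, so there is no measured step on which an expectation could rest, and the three known values all sit close together. For compound 4 the expected step is a 1.0-fold higher number from compound 2 to compound 4 (0.01 log units; within the scatter), which amounts to no change beyond the scatter. Compound 4 is therefore estimated to give 5000 nM, within a range from 2500 nM to 10000 nM.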

Compound 4, half-maximal inhibitory concentration: 7500 nM
Compound 4: the middle estimate sits 1.5-fold (0.18 log units) below what was measured, within the range that was stated.
By their numbers in this assay, from the lowest: compounds 2, 3, 1 and 4 (each within the scatter of the next).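

In this assay, among these compounds, the exchange of 4-bromophenyl for 2,4-dichlorophenyl gives the first step that can be read at this position, a 1.5-fold higher number from compound 2 to compound 4 (0.18 log units; within the scatter), and so it moves the number no further than the scatter. In this one pair, then, a phenyl ring carrying two chlorine atoms on the carbon with a double bond to nitrogen serves no differently from one carrying a single bromine. No other measurement is at hand that bears on this result.

On these data alone, whether a group of another kind at this place, such as an amine, a carboxylic acid or a longer chain, would shift the number beyond the scatter remains open. So does whether the same exchange would leave the number unmoved with the other substituents that compound 1 and compound 3 carry.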